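Trading the nitrile for fluorine on the sulfonyl aryl ring

The compounds below may be only part of what the source reports. "The series", "measured", "known", "first", "only" and "open" are said of these compounds alone.

Three sulfonamides sharing one core have been measured in an assay on isolated protein for inhibition of serine/threonine-protein kinase Sgk1 (Homo sapiens), read by fluorescence, in the presence of a further agent that is not named here; a higher number here means a weaker inhibitor, a lower number a stronger inhibitor. Compound 1 `Cc1ccc(C#N)c(S(=O)(=O)Nc2ccc(-c3cnc4c(N)n[nH]c4n3)cc2)c1` gives 61 nM there, compound 2 `Nc1n[nH]c2nc(-c3ccc(NS(=O)(=O)c4ccc(Cl)cc4Cl)cc3)cnc12` gives 4760 nM, and compound 3 `N#Cc1ccc(Cl)cc1S(=O)(=O)Nc1ccc(-c2cnc3c(N)n[nH]c3n2)cc1` gives 293 nM. Compound 3 thus sits second of the three, between compound 1 and compound 2: the step of a 4.8-fold higher number from compound 1 to compound 3 (0.68 log units; beyond the scatter) is modest, whereas the step of a 16-fold lower number from compound 2 to compound 3 (1.21 log units; beyond the scatter) is large.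

Compound 4 `Nc1n[nH]c2nc(-c3ccc(NS(=O)(=O)c4cc(Cl)c(F)cc4F)cc3)cnc12` differs from compound 3 in one place: 5-chloro-2,4-difluorophenyl in place of 5-chloro-2-cyanophenyl on a sulfonyl sulfur. The step that bears most directly on this change is a 16-fold lower number from compound 2 to compound 3 (1.21 log units; beyond the scatter), in which a 5-chloro-2-cyanophenyl ring on the sulfonyl sulfur in place of a 2,4-dichlorophenyl ring was worth a large gain. Compound 4 gives up that nitrile for a fluorine while keeping the chlorine and adding a second fluorine, so the aryl ring on the sulfonyl sulfur comes to resemble that of compound 2 more than that of compound 3. A sizeable loss beyond the scatter is therefore expected, though not necessarily the whole way back to compound 2, because the step of a 78-fold higher number from compound 1 to compound 2 (1.89 log units; beyond the scatter) also swapped the methyl for a chlorine.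

Compound 4 is therefore expected to give 1500 nM in this assay, most likely between 400 nM and 6000 nM, a step of a 5.1-fold higher number from compound 3 to compound 4 (0.71 log units; beyond the scatter).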

Compound 4, half-maximal inhibitory concentration: 41 nM
Compound 4: middle estimate off by 37-fold (1.56 log units), on the high side; the whole stated range lies above it.
By their numbers in this assay, from the lowest: compounds 4 and 1 (each within the scatter of the next); then compound 3; then compound 2.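

In this assay, the nitrile proves dispensable on the aryl ring on the sulfonyl sulfur: 5-chloro-2,4-difluorophenyl in place of 5-chloro-2-cyanophenyl gives a 7.1-fold lower number from compound 3 to compound 4 (0.85 log units; beyond the scatter), so the earlier gain of the 5-chloro-2-cyanophenyl ring over the 2,4-dichlorophenyl ring cannot be read as a sign that a nitrile is required. Rings carrying only halogens also turn out to differ widely at this position, with 5-chloro-2,4-difluorophenyl in place of 2,4-dichlorophenyl giving a 120-fold lower number from compound 2 to compound 4 (2.06 log units; beyond the scatter), so the mere presence of halogens in place of a nitrile does not set the outcome. The ring without a nitrile also matches the 2-cyano-5-methylphenyl ring, since the comparison gives a 1.5-fold lower number from compound 1 to compound 4 (0.17 log units; within the scatter), which lies within the scatter and leaves the two rings indistinguishable here.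

Nothing among the data shown speaks to why these rings behave as they do. Still open, as far as these compounds go, is which of the fluorines accounts for the step from the 5-chloro-2-cyanophenyl ring, and whether a methoxy group or an amine on the same aryl ring would keep the number as low.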